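N-Acetyl Sulfonamide Variant in the Shared Core Series

This account rests on a few compounds, and the source may have more. Where it says the series, first, only, none or still open, it means among the compounds named here.

Three compounds share the core of compound 1 `CCS(=O)(=O)Nc1ccc(C(C)C(=O)NCc2ccc(C(F)(F)F)nc2N2CCC(C)CC2)cc1F` and differ only at the sulfonamide end. In an assay on cells for antagonist activity at transient receptor potential cation channel subfamily V member 1 (Homo sapiens), read by FLIPR and calcium flux, with a stated time of 15 min (on this read-out lower numbers stand for stronger inhibition and higher numbers for weaker inhibition), compound 1 gives 4.4 nM. Compound 2 `CC1CCN(c2nc(C(F)(F)F)ccc2CNC(=O)C(C)c2ccc(NS(=O)(=O)N(C)C)c(F)c2)CC1` gives 42 nM in this assay, and compound 3 `CC1CCN(c2nc(C(F)(F)F)ccc2CNC(=O)C(C)c2ccc(N(C)S(C)(=O)=O)c(F)c2)CC1` gives 55.5 nM. Compound 3 thus stands at the highest number of the three, with compound 2 within the scatter of it and compound 1 far below it: a 13-fold higher number from compound 1 to compound 3 (1.10 log units; beyond the scatter), while a 1.3-fold higher number from compound 2 to compound 3 (0.12 log units; within the scatter) and a 9.5-fold higher number from compound 1 to compound 2 (0.98 log units; beyond the scatter).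

Compound 4 `CC(=O)N(c1ccc(C(C)C(=O)NCc2ccc(C(F)(F)F)nc2N2CCC(C)CC2)cc1F)S(C)(=O)=O` follows from compound 3 by acetyl in place of methyl on a sulfonamide nitrogen. Among the compounds with values here, no measured step swaps one group for another on a nitrogen that already carries a methyl; the step from compound 1 to compound 3 bears on it only insofar as it shows that filling the sulfonamide nitrogen gave a large rise, whereas the step from compound 2 to compound 3 shows that reshuffling groups around that nitrogen once filled changed little. A small further rise, or no step beyond the scatter, is therefore expected: a 1.6-fold higher number from compound 3 to compound 4 (0.21 log units; within the scatter). For compound 4 the estimate in this assay is 90 nM, within 30 nM to 300 nM.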

Compound 4, inhibition constant: 11.9 nM
Beside the measured number, compound 4's estimate is 7.6-fold (0.88 log units) above it, outside the stated range (below it).
By their numbers in this assay, from the lowest: compound 1; then compound 4; then compounds 2 and 3 (each within the scatter of the next).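

On the sulfonamide nitrogen whose other neighbours are an aromatic carbon and a sulfonyl sulfur, the group added matters once the nitrogen is filled: acetyl in place of methyl gives a 4.7-fold lower number from compound 3 to compound 4 (0.67 log units; beyond the scatter). The acetyl(methylsulfonyl)amino group also stands clear of the (dimethylsulfamoyl)amino group, with a 3.5-fold lower number from compound 2 to compound 4 (0.55 log units; beyond the scatter), but does not fully match the (ethylsulfonyl)amino group, with a 2.7-fold higher number from compound 1 to compound 4 (0.43 log units; beyond the scatter). No evidence at hand accounts for these steps.

The compounds shown leave open whether the lower number from acetyl depends on its carbonyl, which a comparison with an ethyl or a propionyl group on the same nitrogen could test. Compound 4 differs from compound 1 both in carrying acetyl on the sulfonamide nitrogen and in carrying methylsulfonyl instead of ethylsulfonyl. The compounds shown do not separate these two differences, and the acetyl(ethylsulfonyl)amino group could do so.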